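Pyridin-4-yl in place of phenyl on a shared core

A few compounds are considered here, and "the series" means these few. Any claim that something is new, unique, unknown or untested is made for them only; others in the source may bear on it.

Compound 1 `c1ccc(-c2noc(-c3ccncc3)n2)cc1` gives > 1000000 nM in a functional assay on MDA-MB-231 cells (Homo sapiens) for antiproliferative activity, read by MTT assay, with a stated time of 24 h (on this read-out lower numbers stand for stronger inhibition and higher numbers for weaker inhibition), as a limit and not a number. Compound 2 `COc1ccc(-c2noc(-c3ccccc3)n2)cc1OC1CCCC1` gives > 1000000 nM in this assay as a limit too, so it has no number of its own to start from. Compound 3 `COc1ccc(-c2noc(-c3ccncc3)n2)cc1OC1CCCC1` has pyridin-4-yl in place of phenyl on an aromatic carbon of compound 2. Compound 1 already carries pyridin-4-yl and still stands at > 1000000 nM as a limit. In this assay the expected step of an at least 1.4-fold lower number from compound 2 to compound 3 (0.15 log units; that floor lies within the scatter) is none beyond the scatter, with any movement towards stronger inhibition. For compound 3 the estimate is 700000 nM with an expected range of 150000 nM to 2000000 nM in this read-out.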

Compound 3, half-maximal inhibitory concentration: 240000 nM
The estimate for compound 3 lay 2.9-fold (0.46 log units) above the measured number, within the range that was stated.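

Placing pyridin-4-yl on this aromatic carbon of the shared core gives compound 3 a measured number in this assay, with an at least 4.1-fold lower number from compound 2 to compound 3 (0.61 log units; beyond the scatter). Compound 1 also carries pyridin-4-yl, yet its > 1000000 nM remains a limit, so this group does not bring a measured number on every core shown. The step can be given only as a floor because compound 2 sits at a limit: the limit of > 1000000 nM in this assay, at which 2 of the 3 values shown sit.

The compounds shown leave open how pyridin-3-yl or a ring bearing a carboxylic acid would read at this position. They also leave open whether the step would persist with ethoxy in place of cyclopentyloxy.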